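A few compounds are considered here, and "the series" means these few. Any claim that something is new, unique, unknown or untested is made for them only; others in the source may bear on it.

Compound 1 `O=C(O)c1ccccc1-c1ccc(CCc2ncc(Cc3ccccc3F)[nH]2)cc1` — 177 nM
Compound 2 `N#Cc1ccc(Cc2cnc(CCc3ccc(-c4ccccc4C(=O)O)cc3)[nH]2)cc1` — 5890 nM
Compound 3 `CCCCc1cnc(CCc2ccc(-c3ccccc3C(=O)O)cc2)[nH]1` — 2710 nM

These three compounds were measured in an in vitro functional assay on cells for agonist activity at Bombesin receptor subtype-3 (Homo sapiens), read by luminescence and calcium flux; a lower number here means that less compound is needed, a higher number that more compound is needed for the effect. Compound 3 stands second highest of the three numbers: its nearest neighbour is compound 2, which sits a step of a 2.2-fold lower number from compound 2 to compound 3 (0.34 log units; beyond the scatter) away, while compound 1 lies furthest, with a 15-fold higher number from compound 1 to compound 3 (1.18 log units; beyond the scatter) between them. Compound 4 `N#Cc1cccc(Cc2cnc(CCc3ccc(-c4ccccc4C(=O)O)cc3)[nH]2)c1` has not yet been measured. It differs from compound 3 in one place: 3-cyanophenyl in place of propyl on a saturated chain carbon bound to an aromatic carbon, so the saturated chain carbon bound to an aromatic carbon again carries an aryl group, as in compound 1 and compound 2, rather than a chain.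

Among the compounds with values here, two measured steps bear on this change. Replacing 2-fluorophenyl by propyl gave a 15-fold higher number from compound 1 to compound 3 (1.18 log units; beyond the scatter), a large change, whereas replacing 4-cyanophenyl by propyl gave a 2.2-fold lower number from compound 2 to compound 3 (0.34 log units; beyond the scatter), only a modest one. The step from compound 1 to compound 2 shows how far the two aryl groups lie apart from one another: a 33-fold higher number from compound 1 to compound 2 (1.52 log units; beyond the scatter). A 3-cyanophenyl group shares the nitrile with compound 2 and the ring with both, so compound 4 is expected to land between those two, most likely near compound 2 and compound 3, with a step of a 1.1-fold lower number from compound 3 to compound 4 (0.04 log units; within the scatter) expected in this assay. Compound 4 is estimated at 2500 nM, with a range from 500 nM to 9000 nM.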

Compound 4, half-maximal effective concentration: 812 nM
For compound 4 the middle estimate is 3.1-fold (0.49 log units) above the measured one; the measured number falls inside the stated range.
By their numbers in this assay, from the lowest: compound 1; then compound 4; then compound 3; then compound 2.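

In this assay, the two nitrile-bearing aryl groups do not behave alike on the saturated chain carbon bound to an aromatic carbon: 3-cyanophenyl in place of 4-cyanophenyl gives a clear difference (a 7.3-fold lower number from compound 2 to compound 4 (0.86 log units; beyond the scatter)), so the result depends on more than the presence of a nitrile on the ring. Within the data shown here, compound 2 had left the cyanophenyl groups looking no better than the chain, but 3-cyanophenyl in place of propyl now lowers the number (a 3.3-fold lower number from compound 3 to compound 4 (0.52 log units; beyond the scatter)), which means that compound 1 is no longer the only aryl compound below compound 3. Even so, 2-fluorophenyl keeps its lead over 3-cyanophenyl (a 4.6-fold higher number from compound 1 to compound 4 (0.66 log units; beyond the scatter)), and compound 1 remains the lowest of the four.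

No measurement here accounts for these differences between the aryl groups. As far as these compounds go, it remains open whether the order depends chiefly on where the ring carries its substituent or on which substituent it carries, a question that 2-cyanophenyl, 3-fluorophenyl and an unsubstituted phenyl at this place would help to settle.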